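This account rests on a few compounds, and the source may have more. Where it says the series, first, only, none or still open, it means among the compounds named here.

Measured so far in a functional assay on MCF7 cells (Homo sapiens) for cytotoxicity, read by MTT assay, with a stated time of 72 h; on this read-out higher numbers stand for weaker inhibition and lower numbers for stronger inhibition:
compound 1 `CN1[C@@H]2c3[nH]c4ccccc4c3C[C@H]1[C@H](C#N)N1[C@@H](CNC(=O)c3cccc(C(F)(F)F)c3)c3[nH]c4ccccc4c3C[C@@H]21` gives 110 nM;
compound 2 `CN1[C@@H]2c3[nH]c4ccccc4c3C[C@H]1[C@H](C#N)N1[C@@H](CNC(=O)c3ccc(Cl)cc3)c3[nH]c4ccccc4c3C[C@@H]21` gives 610 nM;
compound 3 `CN1[C@@H]2c3[nH]c4ccccc4c3C[C@H]1[C@H](C#N)N1[C@@H](CNC(=O)c3ccc(F)cc3)c3[nH]c4ccccc4c3C[C@@H]21` gives 980 nM.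

Compound 3 has the highest number of the three, with compound 2 nearest and compound 1 furthest; the gap to compound 2 lies within the scatter, the gap to compound 1 beyond it.

Compound 4 `CCc1ccc(C(=O)NC[C@H]2c3[nH]c4ccccc4c3C[C@H]3[C@H]4c5[nH]c6ccccc6c5C[C@@H]([C@H](C#N)N23)N4C)cc1` differs from compound 3 by ethyl in place of fluoro on an aromatic carbon. Among the measured compounds shown here, the only step that bears on this place is a 1.6-fold higher number from compound 2 to compound 3 (0.21 log units; within the scatter), a change of halogen on the same aromatic carbon that stayed within the scatter. The larger steps of a 5.5-fold higher number from compound 1 to compound 2 (0.74 log units; beyond the scatter) and an 8.9-fold higher number from compound 1 to compound 3 (0.95 log units; beyond the scatter) involve a different substituent position and do not directly inform an exchange at this carbon. A modest move, if any, is therefore expected for compound 4 in this assay, a 1.6-fold lower number from compound 3 to compound 4 (0.21 log units; within the scatter). Compound 4 is estimated at 600 nM, range 200 nM to 1800 nM.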

Compound 4, half-maximal inhibitory concentration: 170 nM
For compound 4 the middle estimate is 3.5-fold (0.55 log units) above the measured one; the whole stated range lies above it.
By their numbers in this assay, from the lowest: compounds 1 and 4 (each within the scatter of the next); then compounds 2 and 3 (each within the scatter of the next).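

In this assay this aromatic carbon responds more than the halogen exchange suggested: ethyl in place of fluoro (a 5.8-fold lower number from compound 3 to compound 4 (0.76 log units; beyond the scatter)) and ethyl in place of chloro (a 3.6-fold lower number from compound 2 to compound 4 (0.55 log units; beyond the scatter)) both move beyond the scatter. The 4-ethylphenyl amide also sits within the scatter of the 3-(trifluoromethyl)phenyl amide (a 1.5-fold higher number from compound 1 to compound 4 (0.19 log units; within the scatter)), so that group is not alone at this level. Nothing available here accounts for the effect of ethyl. As far as these compounds go, whether propyl, tert-butyl, methoxy or an amine at this carbon would match ethyl stays open, as does the effect of ethyl at other ring carbons.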